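The source may hold more compounds than are shown below. What is called first, only, known or untested is meant among the compounds shown, and "the series" means these compounds.

Measured so far in an assay on HEK293 cells for displacement of a labelled ligand from NPC1-like intracellular cholesterol transporter 1 (Homo sapiens); on this read-out lower numbers stand for stronger inhibition and higher numbers for weaker inhibition:
- compound 1 `CC(C)(C)OC(=O)NC1CCCN(C(=O)CN2CN(c3ccccc3)C3(CCN(C(=O)c4ccc(C5CCCCC5)cc4)CC3)C2=O)C1` gives 4400 nM
- compound 2 `CC(C)(C)c1ccc(C(=O)N2CCC3(CC2)C(=O)N(CC(=O)N2CCCC(C(N)=O)C2)CN3c2ccccc2)cc1` gives 16900 nM
- compound 3 `CC(C)(C)c1ccc(C(=O)N2CCC3(CC2)C(=O)N(CC(=O)N2CCCC(O)C2)CN3c2ccccc2)cc1` gives 12200 nM

Compound 3 stands second highest of the three numbers; its nearest neighbour is compound 2, which sits within the scatter of it, while compound 1 lies beyond the scatter with the lower number.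

Among the compounds with values here, the one measured step that touches the same place is a 1.4-fold lower number from compound 2 to compound 3 (0.14 log units; within the scatter). It shows that exchanging the group on this saturated ring carbon between carbamoyl and hydroxy left the read-out essentially where it was.

Compound 4 `CC(C)(C)OC(=O)NC1CCCN(C(=O)CN2CN(c3ccccc3)C3(CCN(C(=O)c4ccc(C(C)(C)C)cc4)CC3)C2=O)C1` is not yet measured. Relative to compound 3 it carries (tert-butoxycarbonyl)amino in place of hydroxy on a saturated ring carbon. Compound 1 carries the same (tert-butoxycarbonyl)amino group but differs from compound 3 in a second place as well, so no single step can be read from that pair; its value is merely the lowest of the three shown. Within the data shown here, with the only clean step at this position being within the scatter, the expectation for compound 4 is a modest move at most, if anything toward a lower number, a 1.9-fold lower number from compound 3 to compound 4 (0.27 log units; within the scatter). Compound 4 is thus estimated at 6500 nM, with a range from 2500 nM to 16000 nM.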

Compound 4, half-maximal inhibitory concentration: 4200 nM
Beside the measured number, compound 4's estimate is 1.5-fold (0.19 log units) above it; measured number inside the range.
By their numbers in this assay, from the lowest: compounds 4 and 1 (each within the scatter of the next); then compounds 3 and 2 (each within the scatter of the next).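

In this assay, within the data shown here, the (tert-butoxycarbonyl)amino group gives the first steps beyond the scatter on this saturated ring carbon: a 2.9-fold lower number from compound 3 to compound 4 (0.46 log units; beyond the scatter) against hydroxy and a 4.0-fold lower number from compound 2 to compound 4 (0.60 log units; beyond the scatter) against carbamoyl. The group on this carbon can therefore shift the read-out, although both steps are modest, and the earlier exchange of carbamoyl for hydroxy did not show this. With (tert-butoxycarbonyl)amino on that carbon, the exchange on the aromatic carbon gives a 1.0-fold lower number from compound 1 to compound 4 (0.02 log units; within the scatter), so tert-butyl and cyclohexyl cannot be told apart here, and no data at hand explain either result.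

Which part of the (tert-butoxycarbonyl)amino group carries the step stays open; a free amine or an acetylamino group on the same carbon would separate the nitrogen from the tert-butoxycarbonyl portion. On these data alone, it is also open whether tert-butyl and cyclohexyl stay within the scatter of each other with hydroxy or carbamoyl on the saturated ring carbon, and how a smaller group such as methyl on the aromatic carbon would read.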